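A few compounds are considered here, and "the series" means these few. Any claim that something is new, unique, unknown or untested is made for them only; others in the source may bear on it.

Compound 2 `O=S(=O)(C1=C(Cl)NC2SC=CN12)c1cn(C2CCNC2)c2ncccc12` gives 80 nM in a functional assay on HeLa cells for agonist activity at 5-hydroxytryptamine receptor 6 (Homo sapiens), read by cAMP accumulation and immunoassay (on this read-out higher numbers stand for an effect only at larger amounts of compound and lower numbers for an effect already at smaller amounts), the lowest of the three numbers recorded. Compound 3 `CC(C)N1CCCC(n2cc(S(=O)(=O)c3cccc(F)c3)c3cccnc32)C1` gives 172 nM and compound 1 `O=S(=O)(c1cccc(C(F)(F)F)c1)c1cn(C2CCNC2)c2ncccc12` gives 520 nM; both gaps to compound 2 lie beyond the scatter. Compound 4 `CN1CCCC(n2cc(S(=O)(=O)C3=C(Cl)NC4SC=CN34)c3cccnc32)C1` differs from compound 2 in one place: 1-methylpiperidin-3-yl in place of pyrrolidin-3-yl on an aromatic nitrogen. Among the measured compounds shown here, no measured pair shows this change on its own; compound 1 and compound 3 differ in the ring on the aromatic nitrogen but also in the sulfonyl-linked group, so their values cannot isolate it. Compound 4 is therefore expected to stay near compound 2, with a step from compound 2 to compound 4 of a 1.5-fold higher number from compound 2 to compound 4 (0.18 log units; within the scatter) that is not clearly beyond the scatter. The value for compound 4 is estimated at 120 nM, between 40 nM and 400 nM.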

Compound 4, half-maximal effective concentration: 25 nM
For compound 4 the middle estimate is 4.8-fold (0.68 log units) above the measured one; the measured number lies below the stated range.
By their numbers in this assay, from the lowest: compound 4; then compound 2; then compound 3; then compound 1.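

In this assay, among the compounds shown here, the step from pyrrolidin-3-yl to 1-methylpiperidin-3-yl on the aromatic nitrogen is a 3.2-fold lower number from compound 2 to compound 4 (0.51 log units; beyond the scatter) and is the first change at this position seen on its own. It shows that this position accepts the larger six-membered ring, and that with this sulfonyl-linked group the ring's hydrogen-bond donor is not required for a low number. No data at hand account for the step.

The change alters ring size and nitrogen substitution together, leaving open how 1-methylpyrrolidin-3-yl or unsubstituted piperidin-3-yl would compare. From the compounds shown here alone, whether the step carries over to other sulfonyl-linked groups also remains open.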